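Hydroxybutyl analog of the octyl compound

A few compounds are considered here, and "the series" means these few. Any claim that something is new, unique, unknown or untested is made for them only; others in the source may bear on it.

Compound 1 `CCCCn1nc2ccccc2c1OC` and compound 2 `CCCCCCCCn1nc2ccccc2c1OC` share one core and differ only in the chain on the ring nitrogen. In an assay on isolated protein (urine) for inhibition of Myeloperoxidase (Homo sapiens), read by spectrophotometry (a higher number here means a weaker inhibitor, a lower number a stronger inhibitor), compound 1 gives 910 nM. For compound 2 the result in this assay is > 10000 nM, which is a limit of the assay and not a number, as described in the limit of > 10000 nM in this assay, at which 1 of the 2 values shown sits. Among the compounds with values here, the one measured step, an at least 10-fold higher number from compound 1 to compound 2 (1.04 log units; beyond the scatter), describes butyl in place of hydrogen on a saturated chain carbon, four bonds along the chain from an aromatic nitrogen.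

Compound 3 `COc1c2ccccc2nn1CCCCO` is not yet measured. The change from compound 2 is hydroxy in place of butyl on a saturated chain carbon, four bonds along the chain from an aromatic nitrogen. The measured step bears on the first part of this change, since it runs in the opposite sense: removing the butyl reverses an at least 10-fold higher number from compound 1 to compound 2 (1.04 log units; beyond the scatter), which would carry compound 3 back toward the number seen for compound 1. Within the data shown here, no measured compound shows hydroxy in place of hydrogen at this position, so that part of the change is uncovered. Compound 3 is therefore expected to land near 2000 nM, within 500 nM to 10000 nM, the step of an at least 5.0-fold lower number from compound 2 to compound 3 (0.69 log units; beyond the scatter) being an estimate.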

Compound 3, half-maximal inhibitory concentration: 1790 nM
For compound 3 the middle estimate is 1.1-fold (0.05 log units) above the measured one; low and high end bracket the measured number.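

In this assay, hydroxy in place of butyl on a saturated chain carbon, four bonds along the chain from an aromatic nitrogen, gives an at least 5.5-fold lower number from compound 2 to compound 3 (0.74 log units; beyond the scatter), so this position does not rule out inhibition when the chain carries an added group. Compound 2 stands at a limit of the assay and not at a number, which makes the size of that step only a bound: the limit of > 10000 nM in this assay, at which 1 of the 3 values shown sits.

Hydroxy in place of hydrogen, the part of the change that no earlier pair covered, now has a reading of a 2.0-fold higher number from compound 1 to compound 3 (0.29 log units; within the scatter), which leaves compound 1 and compound 3 within the scatter of each other, so at this position the hydroxy is tolerated but brings no gain that can be read.

From the compounds shown here alone, whether an amine or a carboxylic acid in place of the hydroxy would read the same, and how a longer chain ending in hydroxy would behave, stays open. Going by these compounds, with compound 2 known only as a limit, the chain length at which inhibition is lost between compound 1 and compound 2 is also open.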